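The source may hold more compounds than are shown below. What is called first, only, known or untested is meant among the compounds shown, and "the series" means these compounds.

Measured compounds and their values:
- compound 1, `CCS(=O)(=O)Nc1ccc2c(c1)/C(=C(/NC1CCN(C)CC1)c1ccccc1)C(=O)N2`: > 10 uM
- compound 2, `CC(=O)Nc1ccc2c(c1)/C(=C(/Nc1ccc(CN3CCCCC3)cc1)c1ccccc1)C(=O)N2`: > 6 uM
- compound 3, `CCS(=O)(=O)Nc1ccc2c(c1)/C(=C(\C)Nc1ccc(CN3CCCCC3)cc1)C(=O)N2`: > 6 uM

All three were tested in an ADME assay on HepG2 cells (Homo sapiens) for cytotoxicity, read by MTT assay, with a stated time of 48 h; a lower number here means that less compound is tolerated, a higher number that more compound is tolerated. Compound 1 gave > 10 uM, which is a limit of the assay rather than a number. Compound 2 gave > 6 uM, again a limit and not a number. Compound 3 gave > 6 uM, also a limit. So compound 2 stands nowhere precisely: there is only a limit for it, and the two further values beside it are limits as well, as the limit of > 10 uM in this assay, at which 1 of the 3 values shown sits, and the limit of > 6 uM in this assay, at which 2 of the 3 values shown sit, show. Among the compounds with values here, no step between these measured compounds can be sized.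

Compound 4, `O=C1Nc2ccccc2/C1=C(/Nc1ccc(CN2CCCCC2)cc1)c1ccccc1`, has not yet been measured. It differs from compound 2 in one place: hydrogen in place of acetamido on an aromatic carbon. Within the data shown here, with every measured value sitting at a limit, there is no measured step to lean on, and no change beyond the usual scatter is expected in this assay from this substitution. Compound 4 is therefore expected to give about 10 uM, within a range from 4 uM to 30 uM, most likely again reported only as a limit. This expectation means a step that the limit leaves unreadable from compound 2 to compound 4.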

Compound 4, half-maximal toxic concentration: > 6 uM
Compound 4 was reported as a limit; the forecaster's own chance of this, stated with the estimate: 70%; the middle value lies beyond the limit too.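

Within the data shown here, compound 2 and compound 4 are both reported only as limits in this assay, and no step between them can be read. The compounds shown leave open how much of each compound is actually tolerated, and whether hydrogen in place of acetamido on an aromatic carbon changes that tolerance at all.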